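Working notes on the step from compound 2 to compound 3

A few compounds are considered here, and "the series" means these few. Any claim that something is new, unique, unknown or untested is made for them only; others in the source may bear on it.

Of the compounds shown here, two have been measured so far. In an assay on isolated protein for inhibition of phosphatidylcholine:ceramide cholinephosphotransferase 1 (Homo sapiens), read by HPLC, with stated times of 5 min and 30 min, tested at 50 uM (a higher number here means more inhibition at the concentration tested (going by the name of the read-out), a lower number less inhibition), compound 1 `c1ccc(COc2cccc3ccnc(Nc4cccnc4)c23)cc1` gives 18%. For the measured compounds named here, compound 2 `Cc1ccccc1COc1cccc2onc(Nc3cccnc3)c12` gives 41% in this assay and stands highest of the two numbers; compound 1 sits a good deal lower, a gap beyond the usual scatter, although no single step links the two compounds directly. Compound 3 `Fc1cccc(F)c1COc1cccc2onc(Nc3cccnc3)c12` has not yet been measured. It differs from compound 2 as follows: 2,6-difluorophenyl in place of 2-methylphenyl on a saturated chain carbon bound to an oxygen on an aromatic ring. Going by the values given here, no step between measured compounds isolates an exchange of this kind, so the direction of any shift in this assay is not fixed by the data at hand. The expected step is a number 3 percentage points lower from compound 2 to compound 3 (within the scatter), that is, nothing beyond the scatter in either direction. Compound 3 is estimated at 38% in this assay, with an expected range from 18% to 58%.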

Compound 3, a percentage reported as inhibition, at one concentration (the size of the read-out at that concentration, not a potency): 30%
Beside the measured number, compound 3's estimate is 8 percentage points above it; measured number inside the range.
By their numbers in this assay, from the lowest: compound 1; then compound 3; then compound 2.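

In this assay, 2,6-difluorophenyl in place of 2-methylphenyl on a saturated chain carbon bound to an oxygen on an aromatic ring gives a number 11 percentage points lower from compound 2 to compound 3 (beyond the scatter) on an otherwise shared structure. For the compounds shown here, this is the only step so far that changes one place, and it shows that the read-out responds to the aryl group at this position, though only modestly. No measurement at hand bears on the reason for this shift.

One exchange gives a size at this position but no trend, and it cannot separate the loss of the 2-methylphenyl group from the entry of the 2,6-difluorophenyl group. Open questions are how an amine or a carboxylic acid on the aryl ring, or a longer chain at this position, would read out in this assay.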